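The compounds below may be only part of what the source reports. "The series", "measured", "known", "first", "only" and "open" are said of these compounds alone.

Compound 1, `O=C(Nc1ccc(C(F)(F)F)cc1)N1CCOC2(CCN(C(=O)c3ccco3)CC2)C1`: 75 ug/mL
Compound 2, `CC(C)(C)C(=O)N1CCC2(CC1)CN(C(=O)Nc1ccc(C(F)(F)F)cc1)CCO2`: 73 ug/mL
Compound 3, `O=C(Nc1ccc(C(F)(F)F)cc1)N1CCOC2(CCN(C(=O)c3ccccc3)CC2)C1`: 63 ug/mL

All three compounds share one core and differ only in the group on a carbonyl carbon. In an ADME assay for solubility, in simulated intestinal fluid (on this read-out lower numbers stand for lower solubility and higher numbers for higher solubility), compound 3 gives 63 ug/mL, and its two neighbours sit close by: a 1.2-fold lower number from compound 1 to compound 3 (0.08 log units; within the scatter) and a 1.2-fold lower number from compound 2 to compound 3 (0.06 log units; within the scatter), so the three numbers cannot be told apart with confidence. The remaining step, a 1.0-fold lower number from compound 1 to compound 2 (0.01 log units; within the scatter), is likewise within the scatter.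

Compound 4, `O=C(Nc1ccc(C(F)(F)F)cc1)N1CCOC2(CCN(C(=O)c3cccc(Cl)c3)CC2)C1`, has not yet been measured. It differs from compound 3 in one place: chloro in place of hydrogen on an aromatic carbon. Going by the values given here, none of the measured steps involves a chlorine, so no step among compounds 1, 2 and 3 bears directly on this change. What the measured steps do show is that swapping the whole group on that carbonyl carbon, from furan-2-yl to tert-butyl or to phenyl, left this assay essentially unchanged.

On that basis, the expectation for compound 4 is a number close to that of compound 3, with room for a modest drop: a 1.4-fold lower number from compound 3 to compound 4 (0.15 log units; within the scatter). The estimate for compound 4 is 45 ug/mL, with a range from 15 ug/mL to 100 ug/mL.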

Compound 4, solubility: 21 ug/mL
Compound 4: the middle estimate sits 2.1-fold (0.33 log units) above what was measured; the measured number falls inside the stated range.
By their numbers in this assay, from the lowest: compound 4; then compounds 3, 2 and 1 (each within the scatter of the next).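

In this assay, swapping the whole group on the carbonyl carbon had moved the number by no more than the scatter, yet a single chloro on an aromatic carbon of the phenyl ring gives a step beyond it (a 3.0-fold lower number from compound 3 to compound 4 (0.48 log units; beyond the scatter)), so this part of the molecule is not indifferent to change, and one added heavy atom is enough to show it. The 3-chlorophenyl group also stands apart from the two non-phenyl groups on that carbonyl carbon, both when it replaces tert-butyl (a 3.5-fold lower number from compound 2 to compound 4 (0.54 log units; beyond the scatter)) and when it replaces furan-2-yl (a 3.6-fold lower number from compound 1 to compound 4 (0.55 log units; beyond the scatter)), and all three steps are modest in size. Nothing available here says why the number falls with this change.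

Going by these compounds alone, with only one substituent on this ring, it remains open whether the fall belongs to chlorine itself or would also come with a fluoro, methyl or methoxy group in the same place. Going by these compounds, it is equally open whether an amine or a carboxylic acid on that ring would leave the number lower, restore it or raise it further.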